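Chain-end amine on a trimethoxyphenyl chromone scaffold

This account rests on a few compounds, and the source may have more. Where it says the series, first, only, none or still open, it means among the compounds named here.

Among the measured compounds shown here, compound 2 `CCCCCOc1c(-c2cc(OC)c(OC)c(OC)c2)oc2ccccc2c1=O` carries the highest of the two numbers measured so far; in a functional assay on PC-3 cells (Homo sapiens) for antiproliferative activity, read by WST assay, with a stated time of 3 days (on this read-out lower numbers stand for stronger inhibition and higher numbers for weaker inhibition), compound 2 gives 22200 nM, while compound 1 `CCCCOc1c(-c2cc(OC)c(OC)c(OC)c2)oc2ccccc2c1=O` gives 12800 nM, and the step of a 1.7-fold higher number from compound 1 to compound 2 (0.24 log units; within the scatter) lies within the scatter. Compound 3 `CCN(CC)CCCCOc1c(-c2cc(OC)c(OC)c(OC)c2)oc2ccccc2c1=O` differs from compound 2 by diethylamino in place of methyl on a saturated chain carbon, four bonds along the chain from an oxygen on an aromatic ring. For the measured compounds named here, no measured step exchanges a methyl for a diethylamino, so the lone step from compound 1 to compound 2 bears only loosely on it. Compound 3 is therefore expected to stay near compound 2, with a step of about a 1.5-fold lower number from compound 2 to compound 3 (0.17 log units; within the scatter), estimated at 15000 nM and a range from 4000 nM to 60000 nM.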

Compound 3, half-maximal inhibitory concentration: 13700 nM
Compound 3: middle estimate off by 1.1-fold (0.04 log units), on the high side; measured number inside the range.
By their numbers in this assay, from the lowest: compounds 1, 3 and 2 (each within the scatter of the next).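

In this assay, diethylamino on a saturated chain carbon, four bonds along the chain from an oxygen on an aromatic ring, does not separate from the plain alkyl compounds: replacing methyl gives a 1.6-fold lower number from compound 2 to compound 3 (0.21 log units; within the scatter), and replacing hydrogen gives a 1.1-fold higher number from compound 1 to compound 3 (0.03 log units; within the scatter). A group of five heavy atoms that includes nitrogen thus enters at this position with no change beyond the scatter. No evidence is available that bears on this result. On these data alone, whether a piperidine, a carboxylic acid or a longer chain carrying the diethylamino would move the number beyond the scatter remains open.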